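A carbamate chain replaces methoxy at the assay limit

The source may report more compounds than this note shows. Statements on the series, on what has been measured and on what is new or still open speak of the compounds shown alone.

In an ADME assay on liver for metabolic stability, with Liver microsome (Rattus norvegicus) as the target, read by HPLC, using microsomes (on this read-out lower numbers stand for a shorter-lived compound and higher numbers for a longer-lived compound), compound 2 (`COCCOc1cc2c(-n3nc(-c4ccccn4)nc3N)ncnc2cc1OC`) gives > 4 h as a limit of the assay. Compound 1 (`COCCOc1cc2ncnc(-n3nc(-c4ccccn4)nc3N)c2cc1OCCOC`) gives > 4 h as a limit too. For the measured compounds named here, the only measured step is a step that the two limits leave unreadable from compound 1 to compound 2 and offers no size to carry over. Compound 3 (`COc1cc2ncnc(-n3nc(-c4ccccn4)nc3N)c2cc1OCCCNC(=O)OC(C)C`) carries ((isopropoxycarbonyl)amino)methyl in place of methoxy on a saturated chain carbon, two bonds along the chain from an oxygen on an aromatic ring. Going by the values given here, no measured step bears on this change, so only a tentative, modest shortening is expected in this assay and the reading may again be a limit. The expected change is an at least 1.3-fold lower number from compound 2 to compound 3 (0.12 log units; that floor lies within the scatter) as a rough estimate. The estimate for compound 3 is 3 h (expected range 1 h to 6 h).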

Compound 3, half-life: 1 h
Estimate against measurement, compound 3: 3.0-fold (0.48 log units) above; measured number inside the range.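

For the compounds shown here, compound 3 gives the first readable number at this position: where the step between compound 1 and compound 2 could not be read, 3-((isopropoxycarbonyl)amino)propoxy in place of 2-methoxyethoxy gives an at least 4.0-fold lower number from compound 2 to compound 3 (0.60 log units; beyond the scatter) in this assay. So this position does not always leave the read-out at the limit. The step is only a floor, because compound 2 stands at a limit: the limit of > 4 h in this assay, at which 2 of the 3 values shown sit.

Going by these compounds, whether the change follows the isopropoxycarbonyl end or the longer chain stays open. A free amine or a plain propoxy chain at this position would separate the two.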